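The source may hold more compounds than are shown below. What is called first, only, known or untested is meant among the compounds shown, and "the series" means these compounds.

Compound 1 `CSc1nc2ccccn2c(=N)c1S(=O)(=O)c1ccccc1Cl`: 11 nM
Compound 2 `CSc1nc2ccccn2c(=N)c1S(=O)(=O)c1ccc(C(C)(C)C)cc1`: 65 nM
Compound 3 `C[S+]([O-])c1nc2ccccn2c(=N)c1S(=O)(=O)c1ccccc1`: 250 nM

Of the compounds shown here, three built on a shared core have been measured in an assay on HeLa cells for displacement of a labelled ligand from 5-hydroxytryptamine receptor 6 (Homo sapiens); a higher number here means a weaker inhibitor, a lower number a stronger inhibitor. Compound 1 gives 11 nM, compound 2 gives 65 nM, and compound 3 gives 250 nM. Compound 3 thus stands at the highest number of the three. The nearest to it is compound 2, whose number is lower by an amount beyond the usual scatter, and the furthest is compound 1, lower still. Among the measured compounds shown here, compounds 1 and 2 each differ from compound 3 in more than one place, so no single step between measured compounds can be read off.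

Compound 4 `CCNc1nc2ccccn2c(=N)c1S(=O)(=O)c1ccccc1` has not yet been measured. It departs from compound 3 by a group of 3 heavy atoms (2 carbon, 1 nitrogen; no ring) in place of a group of 3 heavy atoms (1 carbon, 1 oxygen, 1 sulfur; no ring), on an aromatic carbon. For the measured compounds named here, the measured set contains no pair that isolates this exchange, so its effect has to be guessed. The step from compound 3 to compound 4 in this assay is expected to be a 2.5-fold lower number from compound 3 to compound 4 (0.40 log units; beyond the scatter), a modest move toward a lower number, with a real chance that it ends within the scatter. Compound 4 is accordingly estimated to give 100 nM in this assay, within a range from 20 nM to 500 nM.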

Compound 4, half-maximal inhibitory concentration: 2 nM
The estimate for compound 4 lay 50-fold (1.70 log units) above the measured number, and the stated range ends above it.
By their numbers in this assay, from the lowest: compound 4; then compound 1; then compound 2; then compound 3.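

In this assay, the exchange on this aromatic carbon, next to the ring nitrogen, gives a 130-fold lower number from compound 3 to compound 4 (2.10 log units; beyond the scatter), which marks this position as highly sensitive to the group it carries, something that compounds 1, 2 and 3 could not show because they differ in more than one place. The size of the step does not follow a change in heavy-atom count: both groups have 3 heavy atoms and neither has a ring or a net charge, while the counts do differ in that ethylamino brings 1 hydrogen-bond donor and the group it replaces has 0 hydrogen-bond donors. Nothing measured here explains the step, so this difference in counts remains an observation and not a cause.

The compounds shown leave open whether the ethyl chain or the amine hydrogen matters more, a question that a methylamino group, a longer propylamino chain or a dimethylamino group at this carbon could address. They also leave open whether ethylamino would have a similar effect with the chlorine or tert-butyl substituents that compounds 1 and 2 carry on the phenyl ring of the sulfonyl group.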